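The source may report more compounds than this note shows. Statements on the series, on what has been measured and on what is new or still open speak of the compounds shown alone.

The three measured compounds share one core and differ only in the group attached to it. In a functional assay on MCF7 cells (Homo sapiens) for inhibition, read by CCK-8 assay, with a stated time of 48 h (a higher number here means a weaker inhibitor, a lower number a stronger inhibitor), compound 1 `COc1cc(-c2ccnc3cc(-c4ccc(F)cc4)nn23)cc(OC)c1OC` gives 1280 nM, the highest of the three numbers in hand, so it stands as the weakest inhibitor of the set. Compound 2 `COc1cc(-c2ccnc3cc(-c4ccc5ccn(C)c5c4)nn23)cc(OC)c1OC` gives 74 nM, and compound 3 `COc1cc(-c2ccnc3cc(-c4ccc(-c5cnn(C)c5)cc4)nn23)cc(OC)c1OC` gives 274 nM. Both measured steps begin at compound 1: a 17-fold lower number from compound 1 to compound 2 (1.24 log units; beyond the scatter), and a 4.7-fold lower number from compound 1 to compound 3 (0.67 log units; beyond the scatter). In each, a larger group takes the place of the fluoro, and the number falls.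

Compound 4 `COc1cc(-c2ccnc3cc(-c4ccc(C(C)(C)C)cc4)nn23)cc(OC)c1OC` has not yet been measured. Its difference from compound 1 is tert-butyl in place of fluoro on an aromatic carbon. Like the two measured steps, this swaps the fluoro for something larger, but the tert-butyl carries no ring and no hydrogen-bond acceptors, unlike the 1-methyl-1H-pyrazol-4-yl and 1-methyl-1H-indol-6-yl groups that appear in the measured steps. Those steps make a lower number plausible, yet neither is a direct precedent for a group of this kind, so the expected step is kept smaller than either. The estimated step is a 2.6-fold lower number from compound 1 to compound 4 (0.41 log units; beyond the scatter). Compound 4 is therefore expected to give 500 nM, within a range from 200 nM to 1500 nM.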

Compound 4, half-maximal inhibitory concentration: > 10000 nM
Compound 4 was reported as a limit; the forecaster's own chance of this, stated with the estimate: 3%; middle value at least 20-fold (1.30 log units) from the limit.
By their numbers in this assay, from the lowest: compound 2; then compound 3; then compound 1. At a limit, above all of these: compound 4.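

Compound 4 is reported in this assay only as a limit, > 10000 nM, and not as an exact number: the limit of > 10000 nM in this assay, at which 1 of the 4 values shown sits.

This change gives the first step away from the fluoro of compound 1 in which the number rises, an at least 7.8-fold higher number from compound 1 to compound 4 (0.89 log units; beyond the scatter), so a larger group on this aromatic carbon does not by itself bring the number down. The ring-bearing groups stand far from tert-butyl at the same place, with an at least 36-fold higher number from compound 3 to compound 4 (1.56 log units; beyond the scatter) and an at least 130-fold higher number from compound 2 to compound 4 (2.13 log units; beyond the scatter), which shows that the outcome here depends strongly on which group enters, not merely on the fluoro leaving; compound 1 goes against any simple split by rings, since its fluoro has no ring and yet its number is measurable.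

The compounds shown cannot separate the branched shape of tert-butyl from its lack of a ring. An isopropyl, a plain ethyl chain or an amine on the same aromatic carbon would show where, between fluoro and tert-butyl, the number begins to climb.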